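The source may hold more compounds than are shown below. What is called first, only, known or untested is meant among the compounds shown, and "the series" means these compounds.

Values in an assay on HEK293 cells for inhibition of Voltage-dependent T-type calcium channel subunit alpha-1H (Homo sapiens), read by FLIPR and calcium flux, with a stated time of 3 min (on this read-out higher numbers stand for weaker inhibition and lower numbers for stronger inhibition), for the three measured members of the series:

- compound 1 `O=C(Nc1ccc(F)cc1)N1N=C(c2ccc(Br)cc2)CC1c1ccc(F)cc1`: 16 nM
- compound 2 `O=C(NC1CCCCC1)N1N=C(c2ccc(Br)cc2)CC1c1ccc(F)cc1`: 316 nM
- compound 3 `CC(C)NC(=O)N1N=C(c2ccc(Br)cc2)CC1c1ccc(F)cc1`: 382 nM

Compound 3 gives the highest of the three numbers in this assay. Compound 2 is nearest, the step of a 1.2-fold higher number from compound 2 to compound 3 (0.08 log units; within the scatter) lying within the scatter, while compound 1 is furthest, with a 24-fold higher number from compound 1 to compound 3 (1.38 log units; beyond the scatter) well beyond it. Compound 4 `O=C(Nc1ccccn1)N1N=C(c2ccc(Br)cc2)CC1c1ccc(F)cc1` is the next member to be tested; it differs from compound 3 by pyridin-2-yl in place of isopropyl on an amide-type nitrogen.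

Within the data shown here, two measured steps bear on this change, both running in the opposite direction: a 24-fold higher number from compound 1 to compound 3 (1.38 log units; beyond the scatter) and a 20-fold higher number from compound 1 to compound 2 (1.30 log units; beyond the scatter). In each, replacing a six-membered aromatic ring on the amide-type nitrogen with a saturated group raised the number by a large margin, and the two saturated groups gave numbers within the scatter of each other, as a 1.2-fold higher number from compound 2 to compound 3 (0.08 log units; within the scatter) shows. Returning from isopropyl to a six-membered aromatic ring is therefore expected to lower the number markedly, a step estimated at a 9.6-fold lower number from compound 3 to compound 4 (0.98 log units; beyond the scatter). Whether a ring bearing one nitrogen reaches the number of compound 1 cannot be told from these three compounds, so the expectation is set somewhat above it. Compound 4 is estimated at 40 nM, with a range of 10 nM to 160 nM.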

Compound 4, half-maximal inhibitory concentration: 393 nM
Estimate against measurement, compound 4: 9.8-fold (0.99 log units) below; measured number above the stated range.
By their numbers in this assay, from the lowest: compound 1; then compounds 2, 3 and 4 (each within the scatter of the next).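

In this assay, pyridin-2-yl on the amide-type nitrogen gives a number level with those of the saturated groups, with a 1.0-fold higher number from compound 3 to compound 4 (0.01 log units; within the scatter) and a 1.2-fold higher number from compound 2 to compound 4 (0.09 log units; within the scatter) both small, while a 25-fold higher number from compound 1 to compound 4 (1.39 log units; beyond the scatter) is as large as the steps from compound 1 to the isopropyl and cyclohexyl members. A six-membered aromatic ring at this place is therefore not enough on its own to give a number as low as that of compound 1, and compound 4 goes against any reading of the series as aromatic against saturated: among the four compounds, only the 4-fluorophenyl group stands apart. No measurement bears on why the pyridin-2-yl and 4-fluorophenyl groups part so widely.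

The four compounds do not separate the part played by the ring nitrogen of pyridin-2-yl from that of the fluorine of 4-fluorophenyl, and unsubstituted phenyl would fall between these two groups. Pyridin-3-yl, pyridin-4-yl and 4-chlorophenyl at the same place would show whether the high number of compound 4 belongs to pyridine rings generally or to the pyridin-2-yl arrangement alone.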